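Methoxycarbonyl in place of methyl: a half-life question

The compounds below may be only part of what the source reports. "The series", "measured", "known", "first", "only" and "open" are said of these compounds alone.

Measured in an ADME assay (liver) for pharmacokinetics, with Liver microsome (Homo sapiens) as the target, using microsomes; on this read-out lower numbers stand for a shorter-lived compound and higher numbers for a longer-lived compound:
- compound 1 `CCOc1cc(NC(=O)C2(NC(=O)c3ccc4c(C5CCCC5)c(-c5ncc(Cl)cn5)n(C)c4c3)CCC2)ccc1/C=C/C(=O)OCOP(=O)(O)O`: 0.167 h
- compound 2 `CCOC(=O)/C=C/c1ccc(NC(=O)C2(NC(=O)c3ccc4c(C5CCCC5)c(-c5ncc(Cl)cn5)n(C)c4c3)CCC2)cc1OCC`: > 5 h (a limit)
- compound 3 `CCCCCCOC(=O)/C=C/c1ccc(NC(=O)C2(NC(=O)c3ccc4c(C5CCCC5)c(-c5ncc(Cl)cn5)n(C)c4c3)CCC2)cc1OCC`: 17.9 h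

In this assay compound 2 stands at > 5 h and this is a limit, not a number. Compound 4 `CCOc1cc(NC(=O)C2(NC(=O)c3ccc4c(C5CCCC5)c(-c5ncc(Cl)cn5)n(C)c4c3)CCC2)ccc1/C=C/C(=O)OCC(=O)OC` differs from compound 2 at one place (methoxycarbonyl in place of methyl on a saturated chain carbon bound to an oxygen next to a carbonyl group) with methoxycarbonyl in place of methyl on a saturated chain carbon bound to an oxygen next to a carbonyl group. Two measured steps act at that same place, and both are large: first (an at least 29-fold higher number from compound 1 to compound 2 (1.47 log units; beyond the scatter)) and then (a 110-fold higher number from compound 1 to compound 3 (2.03 log units; beyond the scatter)). A third step (a step that the limit leaves unreadable from compound 2 to compound 3) gives no size. Among these compounds the short half-life belongs only to compound 1 (0.167 h) whose group at this place holds oxygen and phosphorus atoms. Methoxycarbonyl also brings oxygen to that place, so compound 4 is expected to move toward compound 1 (0.167 h) without reaching it. The expected change is an at least 3.3-fold lower number from compound 2 to compound 4 (0.52 log units; beyond the scatter) and it would point toward a shorter-lived compound, beyond the scatter. In this assay the estimate for compound 4 is 1.5 h with an expected range from 0.4 h to 6 h.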

Compound 4, half-life: 2.1 h
For compound 4 the middle estimate is 1.4-fold (0.15 log units) below the measured one, and the stated range covers the measured number.
By their numbers in this assay, from the lowest: compound 1; then compound 4; then compound 3.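

In this assay, the saturated chain carbon bound to an oxygen next to a carbonyl group now gives a middle reading rather than only the two ends seen before: methoxycarbonyl shows a 13-fold higher number from compound 1 to compound 4 (1.10 log units; beyond the scatter) and also an 8.5-fold lower number from compound 3 to compound 4 (0.93 log units; beyond the scatter). Among the compounds shown, then, a group holding oxygen at this place does not have to bring the half-life down to that of compound 1, yet compound 4 still stays well short of compound 3, which carries pentyl at the same carbon. Compound 2 stands at a limit of the assay, so an at least 2.3-fold lower number from compound 2 to compound 4 (0.37 log units; beyond the scatter) gives a bound and not a full size, and the step between compound 2 and compound 3 cannot be read: the limit of > 5 h in this assay, at which 1 of the 4 values shown sits.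

As far as these compounds go, it remains open whether the reading of compound 4 goes with the carbonyl of methoxycarbonyl or with its oxygen atoms as such, which a methoxyethyl chain or an amide at this carbon would help to separate. From the compounds shown here alone, it is equally open where a free carboxylic acid would fall on this scale, and whether the low reading of compound 1 needs phosphorus at all.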